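A few compounds are considered here, and "the series" means these few. Any claim that something is new, unique, unknown or untested is made for them only; others in the source may bear on it.

Compound 1 `COc1cccc2cc(C(=O)NC3CCCC3)c(=N)oc12` gives 47% in an assay on HEK293 cells for displacement of a labelled ligand from adenosine receptor A2b (Homo sapiens), read by scintillation counting, with a stated time of 30 min, tested at 10 uM; a higher number here means more inhibition at the concentration tested (going by the name of the read-out), a lower number less inhibition. Compound 2 `CCC(CO)NC(=O)c1cc2cccc(OC)c2oc1=N` gives 39%. Compound 3 `CCC(CO)NC(=O)c1cc2cc(Br)ccc2oc1=N` gives 4%, the lowest of the three.

Between compound 2 and compound 1 the only change is cyclopentyl in place of 1-(hydroxymethyl)propyl on an amide-type nitrogen, and it made the step of a number 8 percentage points higher from compound 2 to compound 1 (within the scatter). Compound 4 `N=c1oc2ccc(Br)cc2cc1C(=O)NC1CCCC1` is not yet measured; it carries the same change relative to compound 3, namely (cyclopentyl in place of 1-(hydroxymethyl)propyl on an amide-type nitrogen), on the same kind of position. The cores of compound 3 and compound 2 differ, but that difference is not broken down here.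

Because the earlier step of a number 8 percentage points higher from compound 2 to compound 1 (within the scatter) from compound 2 to compound 1 stayed within the scatter, a small step is also expected from compound 3 to compound 4, namely a number 6 percentage points higher from compound 3 to compound 4 (within the scatter). Compound 4 is therefore estimated at 10%, most likely between 0% and 25%.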

Compound 4, a percentage reported as inhibition, at one concentration (the size of the read-out at that concentration, not a potency): 28%
Compound 4: the middle estimate sits 18 percentage points below what was measured; measured number above the stated range.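

In this assay, cyclopentyl in place of 1-(hydroxymethyl)propyl on an amide-type nitrogen gives a number 24 percentage points higher from compound 3 to compound 4 (beyond the scatter). Going by these compounds alone, the size of this step therefore did not carry over unchanged from one core to the other: the same change on two cores in this assay, a number 8 percentage points higher (within the scatter) from compound 2 to compound 1 and a number 24 percentage points higher (beyond the scatter) from compound 3 to compound 4, 16 percentage points apart, beyond the scatter of two such steps Only the step on the core of compound 3 lies beyond the scatter, and two pairs cannot show which difference between the cores goes with the larger step, or how the change would behave on a third core.

The compounds shown leave open whether losing the hydroxymethyl group or gaining the ring matters more, which a plain butyl chain on the same nitrogen could help separate. As far as these compounds go, how a chain ending in an amine would fare on either core also remains open.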